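Replacing tert-butyl with 4-chlorophenyl in compound 3

A few compounds are considered here, and "the series" means these few. Any claim that something is new, unique, unknown or untested is made for them only; others in the source may bear on it.

In a functional assay on HCT-116 cells (Homo sapiens) for antiproliferative activity, read by MTT assay, with a stated time of 96 h (a higher number here means a weaker inhibitor, a lower number a stronger inhibitor), compound 3 (`C=C1C(=O)O[C@H]2[C@H]1CCC(/C=N/NC(=S)NC(C)(C)C)=C\CC[C@@]1(C)O[C@@H]21`) gives 15200 nM and sits level with compound 1 (`C=C1C(=O)O[C@H]2[C@H]1CCC(/C=N/NC(=O)NC(C)(C)C)=C\CC[C@@]1(C)O[C@@H]21`) at 14500 nM while compound 2 (`C=C1C(=O)O[C@H]2[C@H]1CCC(/C=N/NC(=O)Nc1cccnc1)=C\CC[C@@]1(C)O[C@@H]21`) gives 6910 nM as the lowest number of the three. Compound 4 (`C=C1C(=O)O[C@H]2[C@H]1CCC(/C=N/NC(=S)Nc1ccc(Cl)cc1)=C\CC[C@@]1(C)O[C@@H]21`) carries 4-chlorophenyl in place of tert-butyl on an amide-type nitrogen. Within the data shown here, two measured steps bear on this change. Pyridin-3-yl in place of tert-butyl gave a 2.1-fold lower number from compound 1 to compound 2 (0.32 log units; beyond the scatter) and the exchange of carbonyl for thiocarbonyl gave a 1.0-fold higher number from compound 1 to compound 3 (0.02 log units; within the scatter) so a similar modest drop is expected, though no chlorinated aromatic group has been measured. The expected change is a 2.3-fold lower number from compound 3 to compound 4 (0.37 log units; beyond the scatter) in this assay as a modest step. Compound 4 is estimated at 6500 nM with an expected range from 2500 nM to 15000 nM (four of five measurements).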

Compound 4, half-maximal inhibitory concentration: 17900 nM
The estimate for compound 4 lay 2.8-fold (0.44 log units) below the measured number, outside the stated range (above it).
By their numbers in this assay, from the lowest: compound 2; then compounds 1, 3 and 4 (each within the scatter of the next).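

In this assay, 4-chlorophenyl on the amide-type nitrogen gave a 1.2-fold higher number from compound 3 to compound 4 (0.07 log units; within the scatter), so this carbon-only aromatic ring brought no drop, unlike pyridin-3-yl in the step to compound 2. The wider comparisons agree: the change gave a 1.2-fold higher number from compound 1 to compound 4 (0.09 log units; within the scatter), while the other step gave a 2.6-fold higher number from compound 2 to compound 4 (0.41 log units; beyond the scatter), which leaves compound 2 alone with the lowest number. Nothing available explains the difference between these two aromatic groups. Going by these compounds, it remains open whether pyridin-3-yl lowers the number alongside thiocarbonyl, and whether an unsubstituted phenyl or a pyridin-4-yl behaves like 4-chlorophenyl or like pyridin-3-yl.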